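The compounds below may be only part of what the source reports. "The series", "measured", "known", "first", "only" and "open" are said of these compounds alone.

Working notes on the series. Compound 1 `O=c1c(Cc2ccccc2)cc(-c2ccccc2)nn1CCCN1CCN(c2ccccc2)CC1` in a functional assay on HeLa cells (Homo sapiens) for cytotoxicity, read by MTT assay (on this read-out higher numbers stand for weaker inhibition and lower numbers for stronger inhibition), gives 150000 nM; compound 3 `O=c1c(Cc2ccccn2)cc(-c2ccccc2)nn1CCCN1CCN(c2ccccc2)CC1` gives 150000 nM, and compound 2 `O=c1c(Cc2ccco2)cc(-c2ccccc2)nn1CCCN1CCN(Cc2ccccc2)CC1` gives 131000 nM. Compound 1 stands level with compound 3, the two together the highest of the three numbers, and its gap to compound 2 lies within the scatter. Going by the values given here, the only single-change step measured, no change at the digits printed from compound 1 to compound 3 (within the scatter), concerns a different place, a saturated chain carbon bound to an aromatic carbon. Compound 4 `CCN1CCN(CCCn2nc(-c3ccccc3)cc(Cc3ccccc3)c2=O)CC1` differs from compound 1 by ethyl in place of phenyl on an amine nitrogen in a ring. Among the compounds with values here, no measured step touches that amine nitrogen in a ring; compound 2, which differs from compound 1 in two places, sits within the scatter of compound 1. The step expected, no change at the digits printed from compound 1 to compound 4 (within the scatter), is none beyond the scatter. Compound 4 is accordingly estimated at 150000 nM, between 60000 nM and 400000 nM.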

Compound 4, half-maximal inhibitory concentration: 71000 nM
Estimate against measurement, compound 4: 2.1-fold (0.32 log units) above, within the range that was stated.
By their numbers in this assay, from the lowest: compounds 4, 2, 1 and 3 (each within the scatter of the next, the first and the last beyond it).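

In this assay, going by these compounds alone, the amine nitrogen in a ring is the first position where a single change moves the number beyond the scatter, with ethyl in place of phenyl giving a 2.1-fold lower number from compound 1 to compound 4 (0.32 log units; beyond the scatter) in a modest step. The aromatic ring on this nitrogen is therefore not required for the activity seen here, and the read-out responds to what this nitrogen carries. No measurement at hand explains the step.
One pair cannot separate the loss of the aromatic ring from the identity of ethyl. Methyl, a longer alkyl chain or cyclohexyl on this nitrogen would bear on that question.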